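A chlorophenyl sulfone swapped for a methoxyphenyl sulfone

A few compounds are considered here, and "the series" means these few. Any claim that something is new, unique, unknown or untested is made for them only; others in the source may bear on it.

Measured so far, in a functional assay on HeLa cells for antagonist activity at 5-hydroxytryptamine receptor 6 (Homo sapiens); a higher number here means a weaker inhibitor, a lower number a stronger inhibitor:
- compound 1 `CCCn1nc(S(=O)(=O)c2cccc3ccccc23)c2cc(N3CCNCC3)ccc21` gives 2.2 nM
- compound 2 `CN1CCN(c2ccc3[nH]nc(S(=O)(=O)c4ccc(Cl)cc4)c3c2)CC1` gives 108 nM
- compound 3 `Cn1nc(S(=O)(=O)c2ccccc2)c2cc(N3CCNCC3)ccc21` gives 3.2 nM

Compound 2 stands apart in this assay as the weakest inhibitor of the three: its number is the highest, and its gaps to compound 3, the nearest, and to compound 1, the furthest, both lie beyond the scatter of repeated measurements.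

Compound 4 `COc1cccc(S(=O)(=O)c2n[nH]c3ccc(N4CCN(C)CC4)cc23)c1` has not yet been measured. It differs from compound 2 in a single place: 3-methoxyphenyl in place of 4-chlorophenyl on a sulfonyl sulfur. The rest of the shared core is left untouched.

Within the data shown here, no measured pair shows this exact change, so nothing in the data tells how the number moves with it. Compounds 1 and 3 do carry other groups on the sulfonyl sulfur, but they also differ from compound 2 elsewhere, so their values cannot be read as a guide to this one swap.

The expected step is therefore a modest one, a 1.4-fold lower number from compound 2 to compound 4 (0.13 log units; within the scatter), toward a somewhat lower number, close to the edge of the scatter. Compound 4 is estimated at 80 nM, with a range from 20 nM to 300 nM.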

Compound 4, half-maximal inhibitory concentration: 57 nM
The estimate for compound 4 lay 1.4-fold (0.15 log units) above the measured number, within the range that was stated.
By their numbers in this assay, from the lowest: compounds 1 and 3 (each within the scatter of the next); then compounds 4 and 2 (each within the scatter of the next).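

In this assay, among these compounds, replacing 4-chlorophenyl with 3-methoxyphenyl gives a 1.9-fold lower number from compound 2 to compound 4 (0.28 log units; within the scatter), the first direct reading of a change on the sulfonyl sulfur with the rest of the shared core held fixed. This step lies within the scatter, so the two groups cannot be told apart in this assay, even though 3-methoxyphenyl adds a hydrogen-bond acceptor that 4-chlorophenyl lacks and carries a different substituent at a different ring position. Nothing available explains why the number stays within the scatter after this swap.

Because both the substituent and its ring position change at once, this pair cannot separate the two, and 3-chlorophenyl or 4-methoxyphenyl on the same core would be needed to do so. Going by these compounds, it also remains open whether a substituent of a different kind on this ring, such as an amine or a carboxylic acid, would move the number beyond the scatter.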